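The compounds below may be only part of what the source reports. "The series", "measured", "known", "first", "only" and "open" are said of these compounds alone.

Compound 2 `COc1cc2c(Oc3ccc(NC(=O)c4cn(-c5ccccc5)nn4)cc3F)ccnc2cc1OCCCN1CCN(C)CC1` stands on the lower of the two numbers in a functional assay on A549 cells (Homo sapiens) for cytotoxicity, read by MTT assay, with a stated time of 72 h (a higher number here means a weaker inhibitor, a lower number a stronger inhibitor), giving 160 nM. Compound 1 `COc1cc2c(Oc3ccc(NC(=O)c4cn(-c5ccccc5C)nn4)cc3F)ccnc2cc1OCCCN1CCC(C)CC1` gives 3500 nM in this assay; it differs from compound 2 in two places, the amine on the chain as well as the aryl on the triazole, so the gap, beyond the scatter, cannot be split between the two changes. Compound 3 `COc1cc2c(Oc3ccc(NC(=O)c4cn(-c5ccccc5C)nn4)cc3F)ccnc2cc1OCCCN1CCN(C)CC1` differs from compound 2 by methyl in place of hydrogen on an aromatic carbon. Among the measured compounds shown here, no single-change step exists to anchor this; a moderate weakening is expected, a 3.8-fold higher number from compound 2 to compound 3 (0.57 log units; beyond the scatter). Compound 3 is estimated at 600 nM, between 200 nM and 2500 nM.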

Compound 3, half-maximal inhibitory concentration: 3100 nM
Estimate against measurement, compound 3: 5.2-fold (0.71 log units) below; the measured number lies above the stated range.
By their numbers in this assay, from the lowest: compound 2; then compounds 3 and 1 (each within the scatter of the next).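

In this assay, methyl in place of hydrogen on the aromatic ring, ortho to a large group, gives a 19-fold higher number from compound 2 to compound 3 (1.29 log units; beyond the scatter), so this position tolerates the change poorly. With 2-methylphenyl held, 4-methylpiperazin-1-yl in place of 4-methylpiperidin-1-yl gives a 1.1-fold lower number from compound 1 to compound 3 (0.05 log units; within the scatter), so on this aryl the two amines are not told apart. Nothing measured here bears on why the methyl costs so much.

Going by these compounds, whether a chlorine or a methoxy group at the same place would do the same remains open. So does whether 4-methylpiperidin-1-yl or a morpholine on the chain would matter with plain phenyl on the triazole.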